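Aryl urea series: butyl to chloro on the aniline ring

The source may hold more compounds than are shown below. What is called first, only, known or untested is meant among the compounds shown, and "the series" means these compounds.

Three compounds of the series have numbers in a functional assay on HEK293 cells for antagonist activity at transient receptor potential cation channel subfamily V member 1 (Rattus norvegicus); on this read-out lower numbers stand for stronger inhibition and higher numbers for weaker inhibition. Compound 1 `CC(C)(C)c1ccc(NC(=S)N2CCN(c3ncccc3C(F)(F)F)CC2)cc1` gives 246 nM. Compound 2 `CC(C)c1ccc(NC(=O)N2CCN(c3ncccc3C=O)CC2)cc1` gives 201 nM. Compound 3 `CCCCc1ccc(NC(=O)N2CCN(c3ncccc3Cl)CC2)cc1` gives 117 nM, the lowest of the three numbers; its gap to compound 2 lies within the scatter, its gap to compound 1 lies just beyond it. Within the data shown here, no two measured compounds differ in a single place, so no isolated structural step can be read from the measured set.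

Compound 4 `O=C(Nc1ccc(Cl)cc1)N1CCN(c2ncccc2Cl)CC1` is not yet measured. It differs from compound 3 in one place: chloro in place of butyl on an aromatic carbon. Among the measured compounds shown here, the only aryl substituents with numbers so far are tert-butyl, isopropyl and butyl, all carbon chains of three or four atoms; a single-atom chloro at the same place has no precedent among the measured compounds, and nothing in the data fixes the direction of the change.

The working expectation is that compound 4 comes out somewhat weaker than compound 3, with a step from compound 3 to compound 4 of a 3.0-fold higher number from compound 3 to compound 4 (0.48 log units; beyond the scatter) in this assay, a step that may or may not clear the scatter. Compound 4 is therefore estimated at 350 nM, with a range from 120 nM to 1200 nM.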

Compound 4, half-maximal inhibitory concentration: 655 nM
Compound 4: the middle estimate sits 1.9-fold (0.27 log units) below what was measured, and the stated range covers the measured number.
By their numbers in this assay, from the lowest: compounds 3, 2 and 1 (each within the scatter of the next, the first and the last beyond it); then compound 4.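

In this assay, the aromatic carbon para to a large group now has its first single-place step: chloro in place of butyl gives a 5.6-fold higher number from compound 3 to compound 4 (0.75 log units; beyond the scatter), a change beyond the scatter. The earlier compounds shown here carried only tert-butyl, isopropyl and butyl here, and they differed elsewhere as well, so they could not show whether this position responds to its substituent on its own. With the rest of the structure held constant, it does respond, and in this pair the butyl chain goes with the stronger inhibition, although no evidence at hand explains the size or direction of this step.

One pair cannot show whether the number rises through loss of the butyl chain or through the arrival of chloro, and the compounds shown leave open how a methyl, a propyl, a hexyl chain, a methoxy group or a bare hydrogen at this place would read on the same core. They also leave open whether the same change would give a step of similar size with the trifluoromethyl or formyl group of the other compounds in place of the chloro on the far ring.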